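Removing a Methoxy Group: Expected Effect on Cytotoxicity

The compounds below may be only part of what the source reports. "The series", "measured", "known", "first", "only" and "open" are said of these compounds alone.

Measured so far:
compound 1, `Cc1nc(C)c(C(=O)Oc2ccccc2/C=C/C(=O)O)nc1C`, 45.7%;
compound 2, `COc1ccc(/C=C/C(=O)O)c(OC(=O)c2nc(C)c(C)nc2C)c1`, 39.7%;
compound 3, `CCOC(=O)/C=C/c1ccc(OC(=O)c2nc(C)c(C)nc2C)c(OC)c1`, 52.4%.

All three were tested in a functional assay on EA.hy 926 cells (Homo sapiens) for cytotoxicity, read by MTT assay, with stated times of 24 h and 12 h, tested at 12.5 uM; a lower number here means a weaker effect, a higher number a stronger effect of the compound at the concentration tested. Compound 3 gives the highest of the three numbers, but only the gap to compound 2 lies beyond the scatter, and its gap to compound 1 is within it. How the core of compound 3 differs from that of compound 2 is not broken down here.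

Compound 1 and compound 2 differ in one place, (hydrogen in place of methoxy on an aromatic carbon), and in this assay this gave a number 6 percentage points higher from compound 2 to compound 1 (within the scatter).

Compound 4, `CCOC(=O)/C=C/c1ccc(OC(=O)c2nc(C)c(C)nc2C)cc1`, has not yet been measured. It differs from compound 3 in one place, (hydrogen in place of methoxy on an aromatic carbon). This is the same kind of change as from compound 2 to compound 1, though the surroundings are not identical: in compound 2 the methoxy sits meta to a large group and para to a 2-carboxyethenyl group, whereas in compound 3 it sits ortho to a large group and meta to a 2-(ethoxycarbonyl)ethenyl group.

Because a number 6 percentage points higher from compound 2 to compound 1 (within the scatter) was within the scatter, the step from compound 3 to compound 4 is expected to be small as well, estimated at a number 2.6 percentage points higher from compound 3 to compound 4 (within the scatter). For compound 4 in this assay the estimated value is 55%, with a range from 42% to 68%.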

Compound 4, a percentage reported as activity, at one concentration (the size of the read-out at that concentration, not a potency): 42.7%
The estimate for compound 4 lay 12.3 percentage points above the measured number; the measured number falls inside the stated range.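

Exchanging the methoxy group for hydrogen on the core of compound 3 gave, in this assay, a number 9.7 percentage points lower from compound 3 to compound 4 (within the scatter). Each step taken alone stays within the usual scatter, but set side by side they do not agree, so in this series the same exchange cannot be carried from one core to the other as a single fixed shift: the same change on two cores in this assay, a number 6 percentage points higher (within the scatter) from compound 2 to compound 1 and a number 9.7 percentage points lower (within the scatter) from compound 3 to compound 4, 15.7 percentage points apart, beyond the scatter of two such steps. Among the compounds shown here, this rests on only two pairs of compounds tested at one concentration, and it does not show why the outcomes part, which feature of the two cores is responsible, or how the change would behave on any further core.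

The compounds shown leave open what a different group at the same place on the aromatic ring, such as an ethoxy group, a fluorine atom or an amine, would do on either core. They also leave open whether the methoxy exchange would follow either earlier step on a core in which the ethyl ester gives way to an amide or a longer alkyl chain.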